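The source may report more compounds than this note shows. Statements on the series, on what has been measured and on what is new or still open speak of the compounds shown alone.

Measured compounds:
Compound 1, `COC(=O)c1nnn([C@@H]2C(=O)N(c3ccc(C)cc3)[C@@H]2/C=C/c2ccccc2)c1C(=O)OC`, gives "not determined" (no result reported) in a functional assay on KB cells (Homo sapiens) for inhibition; a lower number here means a stronger inhibitor, a higher number a weaker inhibitor.
Compound 2, `O=C1[C@@H](n2cc(-c3ccccc3)nn2)[C@@H](/C=C/c2ccccc2)N1c1ccccc1`, gives 91300 nM in this assay.
Compound 3, `COC(=O)c1nnn([C@@H]2C(=O)N(c3ccc(Cl)cc3)[C@@H]2/C=C/c2ccccc2)c1C(=O)OC`, gives 145000 nM in this assay.

Compound 2 has the lowest of the two numbers reported, but its nearest neighbour, compound 3, lies within the usual scatter of it, so the two cannot be told apart. Compound 1 brings no number at all, so only two results set the scene, and both sit at very weak inhibition.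

The next compound to be measured is compound 4, `O=C1[C@@H](n2cc(-c3ccccc3)nn2)[C@@H](/C=C/c2ccccc2)N1c1ccc(Cl)cc1`. Against compound 2 the change is chloro in place of hydrogen on an aromatic carbon. Among the measured compounds shown here, nothing among the measured compounds shows what this change does on its own, and no measured pair differs in one place. For the measured compounds named here, with the two known numbers so close to each other, the step from compound 2 to compound 4 is expected to stay within the scatter, in no clear direction, which as an estimate is a 1.1-fold higher number from compound 2 to compound 4 (0.04 log units; within the scatter). Compound 4 is therefore expected to give about 100000 nM in this assay, with a range from 40000 nM to 250000 nM.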

Compound 4, half-maximal inhibitory concentration: 84200 nM
Compound 4: the middle estimate sits 1.2-fold (0.07 log units) above what was measured; the range from low to high includes it.
By their numbers in this assay, from the lowest: compounds 4, 2 and 3 (each within the scatter of the next).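

Among the compounds shown here, this is the first pair here that differs in only one place, so the change can now be read on its own. In this assay, replacing phenyl with 4-chlorophenyl gives a 1.1-fold lower number from compound 2 to compound 4 (0.04 log units; within the scatter), so chloro at this position, para to a large group, cannot be told apart from hydrogen, and both compounds remain very weak inhibitors. No supporting measurement bears on this result.

From the compounds shown here alone, whether an amine, a methoxy group or a carboxylic acid at this position would shift the number beyond the scatter remains open. Going by these compounds, it is also open whether the same swap would be just as silent in compounds carrying the two methyl esters of compound 3, or whether changes elsewhere on the shared core matter more.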